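The source may report more compounds than this note shows. Statements on the series, on what has been measured and on what is new or still open speak of the compounds shown alone.

The measured compounds:
Compound 1 `Oc1ccc(-c2cc(-c3cccc(F)c3)cc(-c3ccccc3O)n2)cc1` gives in a functional assay on HCT-15 cells (Homo sapiens) for inhibition (a higher number here means a weaker inhibitor, a lower number a stronger inhibitor), the value > 50000 nM, which is a limit of the assay and not a number.
Compound 2 `Oc1ccccc1-c1cc(-c2ccc(C(F)(F)F)cc2)cc(-c2ccccc2O)n1` gives in this assay the value > 50000 nM, again a limit.
Compound 3 `Oc1ccc(-c2cc(-c3ccc(C(F)(F)F)cc3)cc(-c3ccccc3O)n2)cc1` gives in this assay the value > 50000 nM, also a limit.

Compound 3 therefore stands nowhere in particular on these numbers: all three values sit at the same limit (the limit of > 50000 nM in this assay, at which 3 of the 3 values shown sit), so none of the three compounds can be set apart from the others. The change leading to compound 4 `Oc1ccc(-c2cc(-c3ccc(C(F)(F)F)cc3)cc(-c3cccc(O)c3)n2)cc1` is 3-hydroxyphenyl in place of 2-hydroxyphenyl on an aromatic carbon. Two measured steps lead into compound 3 and bear on this change. The shift of a hydroxyphenyl group from compound 2 to compound 3 gave a step that the two limits leave unreadable from compound 2 to compound 3, and the exchange of the fluorinated group from compound 1 to compound 3 gave a step that the two limits leave unreadable from compound 1 to compound 3; neither has a readable size. Nothing in these data shows that relocating the hydroxyl on its ring changes inhibition, and nothing shows that it does not. The expected step is a number no higher from compound 3 to compound 4 (the limit leaves the size open), most likely another limit. Compound 4 is estimated at 50000 nM, within 20000 nM to 150000 nM.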

Compound 4, half-maximal inhibitory concentration: 6440 nM
Estimate against measurement, compound 4: 7.8-fold (0.89 log units) above, outside the stated range (below it).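

Exchanging 2-hydroxyphenyl for 3-hydroxyphenyl next to the ring nitrogen gives, in this assay, an at least 7.7-fold lower number from compound 3 to compound 4 (0.89 log units; beyond the scatter), so where the hydroxyl sits on this one ring matters, even though the two groups have the same atoms. This is the only readable step here, and its full size stays open; the earlier steps cannot be read, and the three earlier compounds cannot be told apart: the limit of > 50000 nM in this assay, at which 3 of the 4 values shown sit.

On these data alone, it remains open whether the 3-hydroxyphenyl group would give a similar result in a compound carrying the 3-fluorophenyl group of compound 1 instead of the 4-(trifluoromethyl)phenyl group. As far as these compounds go, it is also open whether the hydroxyl itself is needed at this place, or whether an amine or a carboxylic acid on the same ring would serve as well.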